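This account rests on a few compounds, and the source may have more. Where it says the series, first, only, none or still open, it means among the compounds named here.

Two compounds sharing a core have numbers in a functional assay on A549 cells (Homo sapiens) for inhibition, read by MTT assay, with a stated time of 72 h; on this read-out lower numbers stand for stronger inhibition and higher numbers for weaker inhibition. Compound 1 (`COc1ccccc1-c1csc2cnc(Nc3ccc(NC(=O)C4CCNCC4)cc3)nc12`) gives 450 nM, and compound 2 (`COc1ccccc1-c1csc2cnc(Nc3ccc(C(=O)NC4CCNCC4)c(C)c3)nc12`) gives 870 nM. These two values lie within the usual scatter of each other, so compound 2 stands level with compound 1 on the numbers available. For the measured compounds named here, the two structures differ in more than one place, and no measured pair isolates a single change.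

Compound 3 (`COc1ccccc1-c1csc2cnc(Nc3ccc(C(=O)NC4CCNCC4)cc3)nc12`) has yet to be measured in this assay. It departs from compound 2 in one place: hydrogen in place of methyl on an aromatic carbon, ortho to a (piperidin-4-yl)carbamoyl group. Going by the values given here, with no measured step for this change, the expectation can rest only on compound 1 at 450 nM and compound 2 at 870 nM. A small shift toward a lower number is expected, but nothing beyond the scatter. The expected step is a 1.5-fold lower number from compound 2 to compound 3 (0.16 log units; within the scatter). For compound 3 the estimated value is 600 nM, within an expected range from 200 nM to 1800 nM.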

Compound 3, half-maximal inhibitory concentration: 360 nM
The estimate for compound 3 lay 1.7-fold (0.22 log units) above the measured number, and the stated range covers the measured number.
By their numbers in this assay, from the lowest: compounds 3, 1 and 2 (each within the scatter of the next, the first and the last beyond it).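

In this assay, the methyl ortho to a (piperidin-4-yl)carbamoyl group now has a measured single-place comparison: hydrogen in its place gives a 2.4-fold lower number from compound 2 to compound 3 (0.38 log units; beyond the scatter), a modest step, so at this position the presence of the methyl separates the two compounds by more than the scatter. For the compounds shown here, the orientation of the amide link can also be read on its own for the first time: (piperidin-4-yl)carbamoyl in place of ((piperidin-4-yl)carbonyl)amino on the aromatic carbon gives a 1.3-fold lower number from compound 1 to compound 3 (0.10 log units; within the scatter), which leaves the two linkages level in this read-out. Nothing available accounts for either step.

The compounds shown leave open whether a fluorine, a chlorine or an ethyl on the same aromatic carbon would read like the hydrogen or like the methyl, and whether the methyl would give a similar step alongside the ((piperidin-4-yl)carbonyl)amino group. Going by these compounds, all three compounds also keep the piperidine unchanged, so the effect of a methyl or an acetyl on its nitrogen remains unknown.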